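Methyl in Place of Bromo: What the Earlier Step Suggests

A few compounds are considered here, and "the series" means these few. Any claim that something is new, unique, unknown or untested is made for them only; others in the source may bear on it.

Of the compounds shown here, three have so far been measured in a functional assay on A549 cells (Homo sapiens) for inhibition, read by sulforhodamine B assay; on this read-out higher numbers stand for weaker inhibition of growth and lower numbers for stronger inhibition of growth. Compound 1, `O=C1NC(=S)S/C1=C\c1cc(Br)ccc1OCc1ccccc1`, gives 7000 nM. Compound 2, `Cc1ccc(OCc2ccccc2)c(/C=C2\SC(=S)NC2=O)c1`, gives 6000 nM. Compound 3, `O=C1NC(=O)/C(=C/c2cc(Br)ccc2OCc2ccccc2)S1`, gives 5000 nM. All three numbers sit within the scatter of one another, so no order among them can be read from these data.

Compound 1 and compound 2 differ in one place: methyl in place of bromo on an aromatic carbon. This change produced a 1.2-fold lower number from compound 1 to compound 2 (0.07 log units; within the scatter). Compound 3 shares its substituent pattern with compound 1 but carries a different core; the difference between the two cores is not broken down here.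

Compound 4, `Cc1ccc(OCc2ccccc2)c(/C=C2\SC(=O)NC2=O)c1`, has not yet been measured. It differs from compound 3 in one place: methyl in place of bromo on an aromatic carbon. This is the same change, at the same place, as the one from compound 1 to compound 2, and it occurs twice among the compounds shown. Among the measured compounds shown here, the only guide to its effect on the core of compound 3 is the single earlier step on the core of compound 1, which stayed within the scatter.

Because the same change gave a 1.2-fold lower number from compound 1 to compound 2 (0.07 log units; within the scatter), compound 4 is expected to stay close to compound 3, and the estimated step is a 1.2-fold lower number from compound 3 to compound 4 (0.08 log units; within the scatter). Compound 4 is therefore expected to give about 4200 nM in this assay, estimated to fall between 2000 nM and 9000 nM.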

Compound 4, concentration for 50% growth inhibition: 8000 nM
Compound 4: the middle estimate sits 1.9-fold (0.28 log units) below what was measured; measured number inside the range.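

In this assay, methyl in place of bromo on an aromatic carbon gave a 1.6-fold higher number from compound 3 to compound 4 (0.20 log units; within the scatter), so on the core of compound 3, as on the core of compound 1, the change left the number within the usual scatter. Set side by side, the two steps cannot be told apart, and the lower number on one core and the higher number on the other should not be read as a real difference between the cores: the same change on two cores in this assay, a 1.2-fold lower number (0.07 log units; within the scatter) from compound 1 to compound 2 and a 1.6-fold higher number (0.20 log units; within the scatter) from compound 3 to compound 4, 1.9-fold (0.27 log units) apart, within the scatter of two such steps. Among the compounds shown here, this shows that, across these two matched pairs and in this one assay, the step taken on one core was a fair guide to the step on the other, but with only two pairs it does not show that the change would behave the same way on any further core, nor does it establish that the bromo and methyl compounds are equal beyond what the scatter can resolve.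

The compounds shown leave open whether a group of another kind at this place on the aromatic ring, such as an amine, a carboxylic acid or a longer chain, would move the number beyond the scatter. They also leave open whether replacing the group of 8 heavy atoms, held constant in all four compounds, would do so.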